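Solubility at low pH: amide in place of imidazole

The source may hold more compounds than are shown below. What is called first, only, known or untested is meant among the compounds shown, and "the series" means these compounds.

Compound 1 `CC(C)C(Cc1ncc[nH]1)c1ccc(-c2ccc3cccc(F)c3c2)[nH]c1=O`: 33800 nM
Compound 2 `CC(C)C(c1ccc(-c2ccc3cccc(F)c3c2)[nH]c1=O)N1CCNC1=O`: 31600 nM

In a physicochemical assay for solubility, measured as kinetic solubility, at pH 2 (a lower number here means a less soluble compound, a higher number a more soluble compound), compound 1 gives 33800 nM, the highest of the two numbers; compound 2 gives 31600 nM, and the step of a 1.1-fold lower number from compound 1 to compound 2 (0.03 log units; within the scatter) is within the scatter. Compound 3 `CC(C)NC(=O)CC(c1ccc(-c2ccc3cccc(F)c3c2)[nH]c1=O)C(C)C` differs from compound 1 by isopropylcarbamoyl in place of 1H-imidazol-2-yl on a saturated chain carbon, two bonds along the chain from an aromatic carbon. For the measured compounds named here, no measured step covers this change; the one step known, from compound 1 to compound 2, replaces a neighbouring group and moves little. A small downward step is expected, a 1.7-fold lower number from compound 1 to compound 3 (0.23 log units; within the scatter), with wide uncertainty. Compound 3 is estimated at 20000 nM, between 6000 nM and 50000 nM.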

Compound 3, solubility: 24200 nM
For compound 3 the middle estimate is 1.2-fold (0.08 log units) below the measured one, and the stated range covers the measured number.
By their numbers in this assay, from the lowest: compounds 3, 2 and 1 (each within the scatter of the next).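

In this assay, isopropylcarbamoyl on a saturated chain carbon, two bonds along the chain from an aromatic carbon, gives a 1.4-fold lower number from compound 1 to compound 3 (0.15 log units; within the scatter), so a group with no ring is not separated here from 1H-imidazol-2-yl. The comparison with the other group gives a 1.3-fold lower number from compound 2 to compound 3 (0.12 log units; within the scatter), which leaves all three compounds within the scatter of one another. Nothing on hand accounts for this lack of separation.

Going by these compounds, whether an amine or a carboxylic acid in place of isopropylcarbamoyl would separate from these three compounds remains open.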